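A few compounds are considered here, and "the series" means these few. Any claim that something is new, unique, unknown or untested is made for them only; others in the source may bear on it.

Measured so far in an ADME assay on BaF3 cells (Mus musculus) for antiproliferative activity, read by CellTiter-Glo and CCK-8 assay, with a stated time of 72 h; on this read-out lower numbers stand for stronger inhibition of growth and higher numbers for weaker inhibition of growth:
compound 1, `Cc1ccc(Nc2ncc3c(n2)N(C)C(=O)N(c2cc(NC(=O)c4cccc(C(F)(F)F)c4)ccc2C)C3)cc1`: 8000 nM.
compound 2, `Cc1ccc(Nc2ncc3c(n2)N(C)C(=O)N(c2cc(NC(=O)c4cccc(C(F)(F)F)c4)ccc2C)C3)cc1N(C)C`: > 10000 nM.
compound 3, `Cc1ccc(NC(=O)c2cccc(C(F)(F)F)c2)cc1NC(=O)c1cnc(Nc2ccc(C)c([N+](=O)[O-])c2)nc1N(C)C`: > 10000 nM.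

For compound 3 the value > 10000 nM is a limit of the assay, not a number. For compound 2 the value > 10000 nM is likewise a limit. Compound 2 and compound 1 differ in one place, (hydrogen in place of dimethylamino on an aromatic carbon), and the change made an at least 1.2-fold lower number from compound 2 to compound 1 (0.09 log units; that floor lies within the scatter); this step is only a floor because of the limit of > 10000 nM in this assay, at which 2 of the 3 values shown sit.

Compound 4, `Cc1ccc(NC(=O)c2cccc(C(F)(F)F)c2)cc1NC(=O)c1cnc(Nc2ccc(C)c([N+](=O)[O-])c2)nc1`, is not yet measured in this assay. It arises from compound 3 by the same kind of change, (hydrogen in place of dimethylamino on an aromatic carbon). The places are not identical: in compound 2 the group sits on a six-membered aromatic ring of carbon only, ortho to a methyl group and meta to a large group, whereas in compound 3 it sits on a six-membered aromatic ring with 2 nitrogen, next to the ring nitrogen, ortho to a large group and opposite the ring nitrogen. The difference between the core of compound 2 and the core of compound 3 is not broken down here.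

The earlier change made only a small step, an at least 1.2-fold lower number from compound 2 to compound 1 (0.09 log units; that floor lies within the scatter). Compound 4 is therefore expected to show a step that the limit leaves unreadable from compound 3 to compound 4. Compound 4 is estimated at 12000 nM, roughly between 5000 nM and 30000 nM, and may again be reported only as a limit.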

Compound 4, concentration for 50% growth inhibition: 8700 nM
Compound 4: the middle estimate sits 1.4-fold (0.14 log units) above what was measured, and the stated range covers the measured number.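

Replacing the dimethylamino group with hydrogen gives, in this assay, an at least 1.1-fold lower number from compound 3 to compound 4 (0.06 log units; that floor lies within the scatter). The same change can now be followed on two cores, and on each it leads from a limit of the assay to a measured number, but the two steps cannot be compared in size: the same change on two cores in this assay, an at least 1.2-fold lower number (0.09 log units; that floor lies within the scatter) from compound 2 to compound 1 and an at least 1.1-fold lower number (0.06 log units; that floor lies within the scatter) from compound 3 to compound 4; the limit leaves it open whether they differ. So the series shows that the change can be made on both cores without the measured number rising past the limit, and it does not show that the change has the same effect on each, since the starting value on both cores is only a limit: the limit of > 10000 nM in this assay, at which 2 of the 4 values shown sit.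

The compounds shown leave open whether another group at this place, such as a primary amine, a carboxylic acid or a longer chain, would bring a clearly lower number on either core. Compound 1 and compound 4 differ in more than one place, and so the two cores themselves still lack a clean one-place comparison.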